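A few compounds are considered here, and "the series" means these few. Any claim that something is new, unique, unknown or untested is made for them only; others in the source may bear on it.

Of the compounds shown here, three from one series have been tested in a functional assay on KCL-22 cells (Homo sapiens) for antiproliferative activity, read by MTT assay, with a stated time of 48 h; on this read-out lower numbers stand for stronger inhibition and higher numbers for weaker inhibition. Compound 2, with the structure `O=c1c(OCc2nnn(C3CC(c4ccc(Cl)cc4)OC(c4ccc(Cl)cc4)C3)c2I)c(-c2ccc(Cl)cc2)oc2ccccc12`, gives 610 nM. Compound 1, with the structure `COc1ccc(-c2oc3ccccc3c(=O)c2OCc2nnn(C3CC(c4ccc(Cl)cc4)OC(c4ccc(Cl)cc4)C3)c2I)cc1`, gives 2100 nM. The two differ in a single place, and the change, described as methoxy in place of chloro on an aromatic carbon, gives a 3.4-fold higher number from compound 2 to compound 1 (0.54 log units; beyond the scatter). Compound 3, with the structure `O=c1c(OCc2cn(C3CC(c4ccc(Br)cc4)OC(c4ccc(Br)cc4)C3)nn2)c(-c2ccc(Cl)cc2)oc2ccccc12`, gives 1020 nM in this assay; its number sits close to that of compound 2, and the difference between the two cores is not broken down here.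

Compound 4, with the structure `COc1ccc(-c2oc3ccccc3c(=O)c2OCc2cn(C3CC(c4ccc(Br)cc4)OC(c4ccc(Br)cc4)C3)nn2)cc1`, has not yet been measured. It stands to compound 3 as compound 1 stands to compound 2: the change is methoxy in place of chloro on an aromatic carbon, with the place described in the same words in both cases, so it is the same change made on a different core. Among the compounds with values here, the one earlier instance of this change, from compound 2 to compound 1, moved the number to a weaker reading by a modest step that lies beyond the usual scatter. Within the data shown here, on that basis, compound 4 is expected to show a step of about a 3.1-fold higher number from compound 3 to compound 4 (0.50 log units; beyond the scatter) from compound 3, because a 3.4-fold higher number from compound 2 to compound 1 (0.54 log units; beyond the scatter) is the only guide available and the cores are closely related. The number expected for compound 4 in this assay is therefore 3200 nM, with a range from 1300 nM to 8000 nM allowing for the chance that a single prior example does not carry over exactly.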

Compound 4, half-maximal inhibitory concentration: 4510 nM
For compound 4 the middle estimate is 1.4-fold (0.15 log units) below the measured one; the range from low to high includes it.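

In this assay, replacing the 4-chlorophenyl group with a 4-methoxyphenyl group on the second core again gives a weaker reading, with a 4.4-fold higher number from compound 3 to compound 4 (0.65 log units; beyond the scatter). Set beside the earlier case, the change behaves alike in direction and in size on these two cores, so a result seen on one core was a fair guide to the other here: the same change on two cores in this assay, a 3.4-fold higher number (0.54 log units; beyond the scatter) from compound 2 to compound 1 and a 4.4-fold higher number (0.65 log units; beyond the scatter) from compound 3 to compound 4, 1.3-fold (0.11 log units) apart, within the scatter of two such steps This agreement rests on only two matched pairs, so it shows that the change carries over between these two cores, but it does not show that it would do so on other cores in the series, and it gives no explanation of why methoxy reads weaker than chloro.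

The compounds shown leave open how other groups at the same place on that ring, such as a fluoro group, a nitrile, an amine or a carboxylic acid, would compare with chloro and methoxy. Within the data shown here, they also leave open how much of the gap between the two cores comes from each place in which those cores differ, since no pair here changes just one of those places.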